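A few compounds are considered here, and "the series" means these few. Any claim that something is new, unique, unknown or untested is made for them only; others in the source may bear on it.

The compounds share one saturated bicyclic core carrying an amine, and they differ only in the aromatic ring attached through a saturated chain carbon to that amine nitrogen. Compound 1 `C[C@H]1[C@H](NCc2cncs2)C[C@H]2C[C@@H]1C2(C)C` carries a 1,3-thiazol-5-yl group, compound 3 `C[C@H]1[C@H](NCc2cnccn2)C[C@H]2C[C@@H]1C2(C)C` a pyrazin-2-yl group, and compound 2 `CCc1ccc(CN[C@@H]2C[C@H]3C[C@@H]([C@H]2C)C3(C)C)s1` a thiophene ring bearing an ethyl group. In an ADME assay on MDCK cells (Canis lupus familiaris) for cytotoxicity, read by microscopy, with a stated time of 48 h (a higher number here means that more compound is tolerated, a lower number that less compound is tolerated), compound 1 reaches only a limit of the assay, > 100000 nM. Compound 3 likewise gives only a limit in this assay, > 100000 nM. Compound 2, by contrast, gives a real number in this assay, 1560 nM. The step that the two limits leave unreadable from compound 1 to compound 3 cannot be sized because of the limit of > 100000 nM in this assay, at which 2 of the 3 values shown sit, so compound 3 stands at the limit, with compound 1 at the same limit and compound 2 clearly less tolerated.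

Compound 4 `C[C@H]1[C@H](NCc2ccc(Cl)s2)C[C@H]2C[C@@H]1C2(C)C` brings the change (5-chlorothiophen-2-yl in place of pyrazin-2-yl on a saturated chain carbon bound to an amine nitrogen). Among the compounds with values here, no measured step covers this change directly, and the one measured step is unreadable. Within the data shown here, what the numbers show is that the single compound with a substituted thiophene, compound 2, was tolerated less than the two compounds with a pyrazin-2-yl or 1,3-thiazol-5-yl group. Compound 4 is therefore expected to move away from the limit by an at least 12-fold lower number from compound 3 to compound 4 (1.09 log units; beyond the scatter), though with wide uncertainty. The estimate for compound 4 is 8000 nM, ranging from 1500 nM to 100000 nM.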

Compound 4, minimum cytotoxic concentration: 25000 nM
The estimate for compound 4 lay 3.1-fold (0.49 log units) below the measured number; measured number inside the range.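

In this assay, the effect of the group on a saturated chain carbon bound to an amine nitrogen no longer rests on compound 2 alone: the 5-chlorothiophen-2-yl group gives an at least 4.0-fold lower number from compound 3 to compound 4 (0.60 log units; beyond the scatter), and it also gives an at least 4.0-fold lower number from compound 1 to compound 4 (0.60 log units; beyond the scatter). These two steps have only a minimum size, and the comparison between the pyrazin-2-yl and 1,3-thiazol-5-yl compounds remains unreadable, all for one reason: the limit of > 100000 nM in this assay, at which 2 of the 4 values shown sit. The thiophene ring alone does not set the number, since chloro in place of ethyl on an aromatic carbon gives a 16-fold higher number from compound 2 to compound 4 (1.20 log units; beyond the scatter), so the group carried by that ring also matters here.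

The compounds shown leave open how a thiophene ring with no added group, or one carrying methyl or methoxy, would read in this assay, so two thiophene substituents cannot yet define a trend. They also leave open whether a plain phenyl ring on the same chain carbon would behave more like the 5-chlorothiophen-2-yl group or the pyrazin-2-yl group.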